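The source may report more compounds than this note shows. Statements on the series, on what has been measured and on what is new or still open speak of the compounds shown alone.

Compound 1 `Nc1nc(NCc2ccccc2)c2ncn(/C=C3/CC3(CO)CO)c2n1` — > 20000 nM
Compound 2 `CCCCNc1nc(N)nc2c1ncn2/C=C1/CC1(CO)CO` — > 20000 nM
Compound 3 `Nc1nc(N2CCCC2)c2ncn(/C=C3/CC3(CO)CO)c2n1` — > 20000 nM

Of the compounds shown here, three on a shared core have been tested in an ADME assay on CCRF-HSB-2 cells (Homo sapiens) for cytotoxicity, with a stated time of 7 days; a higher number here means that more compound is tolerated, a lower number that less compound is tolerated. In this assay compound 1 gives > 20000 nM, which is a limit of the assay and not a number. Compound 2 likewise gives > 20000 nM, again a limit. Compound 3 gives > 20000 nM, also a limit. None of the three steps between them can be read: a step that the two limits leave unreadable from compound 1 to compound 2, a step that the two limits leave unreadable from compound 1 to compound 3 and a step that the two limits leave unreadable from compound 2 to compound 3 are all hidden by the two limits. For the measured compounds named here, the one piece of evidence that does stand out is the limit of > 20000 nM in this assay, at which 3 of the 3 values shown sit.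

Compound 3 therefore sits at the same limit as the other two measured compounds, with no number of its own. The unmeasured compound 4 `COCCOc1nc(N)nc2c1ncn2/C=C1/CC1(CO)CO` differs from it in one place: 2-methoxyethoxy in place of pyrrolidin-1-yl on an aromatic carbon. Going by the values given here, no measured step bears on this change, since every step so far has been unreadable, and the three exchanges at this aromatic carbon have so far left the read-out at its limit. Compound 4 is therefore expected to stay at the limit too, with a number no higher from compound 3 to compound 4 (the limit leaves the size open) as the expected step. The estimate for compound 4 in this assay is 20000 nM, from 10000 nM to 40000 nM.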

Compound 4, half-maximal cytotoxic concentration: > 20000 nM
Compound 4: only a limit was reported (the forecaster's own chance of this, stated with the estimate: 85%); the middle value lies on the limit itself.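

In this assay compound 4 gives > 20000 nM, which is a limit of the assay and not a number. No step from compound 1, compound 2 or compound 3 to compound 4 can be read, because all four compounds rest at the same limit: the limit of > 20000 nM in this assay, at which 4 of the 4 values shown sit.

The compounds shown leave open whether benzylamino, butylamino, pyrrolidin-1-yl and 2-methoxyethoxy on this aromatic carbon differ at all in this assay.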